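The compounds below may be only part of what the source reports. "The series", "measured", "known", "first", "only" and "open" are said of these compounds alone.

- compound 1 `CC(C)[C@H](NC(=O)COc1cccc2ccccc12)C(=O)N[C@@H](CC(=O)O)C(=O)COc1ccc(-c2ccccc2)cc1` gives 87900 nM in the assay below
- compound 2 `CC(C)[C@H](NC(=O)COc1cccc2ccccc12)C(=O)N[C@@H](CC(=O)O)C(=O)COc1ccc(OC(F)(F)F)cc1` gives 29100 nM in the same assay

Both numbers come from a functional assay on Jurkat cells (Homo sapiens) (a lower number here means a stronger inhibitor, a higher number a weaker inhibitor), and, of the two, compound 2 stands lowest. Among the compounds with values here, compound 3 `CC(C)[C@H](NC(=O)COc1cccc2ccccc12)C(=O)N[C@@H](CC(=O)O)C(=O)COc1ccc(Oc2ccc(C(F)(F)F)cc2)cc1` has no measurement yet. It differs from compound 2 in one place (4-(trifluoromethyl)phenyl in place of trifluoromethyl on an oxygen on an aromatic ring) with 4-(trifluoromethyl)phenyl in place of trifluoromethyl on an oxygen on an aromatic ring.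

Within the data shown here, only one measured step bears on this change. In a 3.0-fold lower number from compound 1 to compound 2 (0.48 log units; beyond the scatter) the swap was trifluoromethoxy in place of phenyl on an aromatic carbon, a modest step beyond the scatter. Among the measured compounds shown here, it is only an indirect guide, since no measured compound carries a ring on that oxygen. For the measured compounds named here, still, the one measured compound with an added aromatic ring there, compound 1 at 87900 nM, has the higher number. A modest step of about that size is therefore expected in this assay, upward and back towards compound 1. The expected change is a 2.1-fold higher number from compound 2 to compound 3 (0.31 log units; beyond the scatter) and it could turn out smaller. Compound 3 is estimated at 60000 nM with 20000 nM to 150000 nM as the expected range.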

Compound 3, half-maximal inhibitory concentration: 9300 nM
The estimate for compound 3 lay 6.5-fold (0.81 log units) above the measured number; the whole stated range lies above it.
By their numbers in this assay, from the lowest: compound 3; then compound 2; then compound 1.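

In this assay the 4-(trifluoromethyl)phenyl group on the oxygen on the aromatic ring gave the lower number (a 3.1-fold lower number from compound 2 to compound 3 (0.50 log units; beyond the scatter)), so a larger group carrying an aromatic ring is tolerated at this place, something compound 1 alone had not suggested. The comparison with compound 1 (a 9.5-fold lower number from compound 1 to compound 3 (0.98 log units; beyond the scatter)) shows that two compounds with an added aromatic ring can stand at opposite ends of the order, so the presence of that ring does not by itself set the number among these three compounds. Nothing available here explains why the larger group gives the lower number.

Because compound 1 and compound 3 differ by both the oxygen link and the trifluoromethyl group, these compounds cannot show which of the two accounts for the gap between them. A plain phenoxy group would separate the two contributions, and a benzyloxy group or a 4-chlorophenoxy group would show whether the link length or the trifluoromethyl group itself matters at this place.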